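From a Chlorophenyl Limit to a Dinitrophenyl Expectation

The compounds below may be only part of what the source reports. "The series", "measured", "known", "first", "only" and "open" are said of these compounds alone.

Of the compounds shown here, two have so far been tested in a functional assay on A549 cells (Homo sapiens) for antiproliferative activity, read by MTT assay, with a stated time of 48 h; on this read-out higher numbers stand for weaker inhibition and lower numbers for stronger inhibition. Compound 1 `N#CC1=C(N)Oc2c(c3nc4ccccc4nc3c3ccccc23)C12C(=O)N(Cc1cnnn1-c1cccc(Br)c1)c1ccccc12` gives > 50000 nM, which is a limit of the assay rather than a number. Compound 2 `N#CC1=C(N)Oc2c(N)cc3nc4ccccc4nc3c2C12C(=O)N(Cc1cnnn1-c1ccc(Cl)cc1)c1ccccc12` gives > 50000 nM, again a limit and not a number. Where compound 2 stands is therefore told only by the limit of > 50000 nM in this assay, at which 2 of the 2 values shown sit: both values rest at that limit, and no step between measured compounds can be counted.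

Compound 3 `N#CC1=C(N)Oc2c(N)cc3nc4ccccc4nc3c2C12C(=O)N(Cc1cnnn1-c1ccc([N+](=O)[O-])cc1[N+](=O)[O-])c1ccccc12` has not yet been measured. It differs from compound 2 in one place: 2,4-dinitrophenyl in place of 4-chlorophenyl on an aromatic nitrogen. Among the measured compounds shown here, no measured step in this assay speaks to this change, and neither measured compound has reached a number. The expected step is a step that the limit leaves unreadable from compound 2 to compound 3, which is to say none beyond the usual scatter, with the value most likely remaining a limit. Compound 3 is estimated at 60000 nM, in the range 20000 nM to 200000 nM.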

Compound 3, half-maximal inhibitory concentration: > 50000 nM
Compound 3 gave a limit, no number; the forecaster's own chance of this, stated with the estimate: 75%; the middle value lies beyond the limit too.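

In this assay compound 3 gives > 50000 nM, which is a limit and not a number. Among the compounds shown here, compound 2 also rests at a limit, so no step between compound 2 and compound 3 can be read. The compounds shown leave open how the group on the aromatic nitrogen bears on activity, as none of them gives a number: the limit of > 50000 nM in this assay, at which 3 of the 3 values shown sit.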